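This account rests on a few compounds, and the source may have more. Where it says the series, first, only, none or still open, it means among the compounds named here.

In a functional assay on HeLa cells (Homo sapiens) for cytotoxicity, read by MTT assay, with a stated time of 24 h (a lower number here means a stronger inhibitor, a higher number a weaker inhibitor), compound 1 (`CCCCCCCCCCCC(=O)Nc1nnc(S[C@@H]2O[C@H](COC(C)=O)[C@H](OC(C)=O)[C@H](OC(C)=O)[C@H]2OC(C)=O)s1`) gives 51900 nM, while compound 2 (`CCCCCCCCCCCCCCCCCC(=O)Nc1nnc(S[C@@H]2O[C@H](CO)[C@H](O)[C@H](O)[C@H]2O)s1`) gives 11200 nM. That is the lower of the two numbers, making compound 2 the stronger inhibitor by a gap beyond the usual scatter. These two compounds differ in more than one place, so their gap cannot be pinned on any single change. Compound 3 (`CCCCCCCC(=O)Nc1nnc(S[C@@H]2O[C@H](CO)[C@H](O)[C@H](O)[C@H]2O)s1`) differs from compound 2 in one place, with hydrogen in place of decyl on a saturated chain carbon, seven bonds along the chain from a carbonyl carbon. Among the measured compounds shown here, no measured pair isolates this change, so the expectation is only a judgement, and it is held loosely. The expected step of a 3.1-fold higher number from compound 2 to compound 3 (0.49 log units; beyond the scatter) is a moderate one toward a weaker number, beyond the scatter. For compound 3 the estimated value is 35000 nM, with an expected range of 11000 nM to 110000 nM.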

Compound 3, half-maximal inhibitory concentration: 50800 nM
Compound 3: the middle estimate sits 1.5-fold (0.16 log units) below what was measured; the measured number falls inside the stated range.
By their numbers in this assay, from the lowest: compound 2; then compounds 3 and 1 (each within the scatter of the next).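

In this assay the loss of the decyl, with hydrogen in its place on a saturated chain carbon, seven bonds along the chain from a carbonyl carbon, gives a clear change (a 4.5-fold higher number from compound 2 to compound 3 (0.66 log units; beyond the scatter)). Among the compounds shown here, this is the first comparison in which only one part of the molecule differs, so this gap, unlike the one between compound 1 and compound 2, can be tied to a single change: the decyl counts at this position, and the step lies beyond the scatter. For the compounds shown here, no supporting information on the cause accompanies this step, so the result shows only that the number changes, not the reason.

Still open is how the number changes with chain length, since a dodecyl or other longer chain and a shorter butyl at this position are not among the compounds shown. On these data alone, it is also open how a chain ending in an amine or a carboxylic acid would compare with the decyl.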